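Swapping a Benzyl Group Where Solubility Held Steady

A few compounds are considered here, and "the series" means these few. Any claim that something is new, unique, unknown or untested is made for them only; others in the source may bear on it.

Of the compounds shown here, three built on a shared core have been measured in a physicochemical assay for solubility, with a stated time of 18 h, at pH 7.4; on this read-out lower numbers stand for lower solubility and higher numbers for higher solubility. Compound 1 `COc1cccc(CNCCCNc2ccnc3cc(Cc4cc(C)cc(C)c4)ccc23)c1O` gives 4200 nM. Compound 2 `COc1cccc(CNCCCNc2ccnc3cc(Cc4ccc(F)cc4)ccc23)c1O` gives 4200 nM in this assay, and compound 3 `COc1ccc(F)cc1CNCCCNc1ccnc2cc(Cc3ccc(F)cc3)ccc12` gives 4200 nM in this assay. Compound 1 and compound 2 differ in a single place: 3,5-dimethylphenyl in place of 4-fluorophenyl on a saturated chain carbon bound to an aromatic carbon. That exchange made the step of no change at the digits printed from compound 2 to compound 1 (within the scatter). Compound 3 differs from compound 2 in another place: 5-fluoro-2-methoxyphenyl in place of 2-hydroxy-3-methoxyphenyl on a saturated chain carbon bound to an amine nitrogen, and this exchange made the step of no change at the digits printed from compound 2 to compound 3 (within the scatter). All three values thus sit level with one another, with no step beyond the scatter among them.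

Compound 4 `COc1ccc(F)cc1CNCCCNc1ccnc2cc(Cc3cc(C)cc(C)c3)ccc12` has not yet been measured in this assay. It differs from compound 3 by 3,5-dimethylphenyl in place of 4-fluorophenyl on a saturated chain carbon bound to an aromatic carbon. This is the same change that turns compound 2 into compound 1, at the same place, only made now on the core of compound 3 rather than the core of compound 2; how those two cores differ is the exchange already described between compound 2 and compound 3.

Resting on the measured step of no change at the digits printed from compound 2 to compound 1 (within the scatter), the expected step is no change at the digits printed from compound 3 to compound 4 (within the scatter), a step that should stay within the scatter. For compound 4 the estimated solubility is therefore 4200 nM, with four of five repeat measurements expected to fall between 2100 nM and 8400 nM. The measurement itself is what comes next.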

Compound 4, solubility: 4200 nM
For compound 4 middle estimate and measured number coincide at the digits printed, and the stated range covers the measured number.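

In this assay, putting 3,5-dimethylphenyl in place of 4-fluorophenyl gave no change at the digits printed from compound 3 to compound 4 (within the scatter), matching the same exchange on the other core, which gave no change at the digits printed from compound 2 to compound 1 (within the scatter); the exchange between the two cores, read here with 3,5-dimethylphenyl in place, likewise gave no change at the digits printed from compound 1 to compound 4 (within the scatter). This shows that, for these four compounds, the benzyl change had the same outcome on both cores, but it is only a match between two flat steps, so it does not test whether a change that really shifts solubility would carry across in the same way, and two cores make no rule for the wider series. No measurement shown here speaks to why all four values stay level.

The compounds shown leave open what happens when something quite different sits on the saturated chain carbon bound to an aromatic carbon, such as an amine or a carboxylic acid in place of these two aromatic rings. They also leave open whether a longer chain in the part joining the two amine nitrogens would keep the read-out level, and whether the benzyl change would carry across cores in any other kind of assay.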